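From 4-methoxyphenyl to 3-chlorophenyl on a weak antiproliferative compound

The source may report more compounds than this note shows. Statements on the series, on what has been measured and on what is new or still open speak of the compounds shown alone.

In a functional assay on HCT-116 cells (Homo sapiens) for antiproliferative activity, with a stated time of 72 h (on this read-out higher numbers stand for weaker inhibition and lower numbers for stronger inhibition), compound 1 (`COc1ccc(/C=C/c2nc3ccccc3c(=O)[nH]2)cc1`) gives > 25000 nM and this is a limit of the assay, not a number. Going by the values given here, compound 2 (`COc1ccc(/C=C/c2nc(Nc3cccc(O)c3)c3ccccc3n2)cc1`) gives 22900 nM and so holds the only actual number so far. Compound 3 (`Oc1cccc(Nc2nc(/C=C/c3cccc(Cl)c3)nc3ccccc23)c1`) is still unmeasured, with 3-chlorophenyl in place of 4-methoxyphenyl on a double-bonded chain carbon bound to a double-bonded chain carbon. Among the compounds with values here, no measured step guides this swap, so only a small expected step (a 1.9-fold lower number from compound 2 to compound 3 (0.28 log units; within the scatter)) toward stronger inhibition is estimated, within the usual scatter. The estimate for compound 3 is 12000 nM (expected range from 4000 nM to 25000 nM).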

Compound 3, half-maximal inhibitory concentration: > 25000 nM
Compound 3: no number, only a limit; the forecaster's own chance of this, stated with the estimate: 25%; middle value at least 2.0-fold (0.31 log units) away from the limit.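

In this assay, the change to 3-chlorophenyl gives an at least 1.0-fold higher number from compound 2 to compound 3 (0.03 log units; that floor lies within the scatter), so this swap on a double-bonded chain carbon bound to a double-bonded chain carbon brings no gain in inhibition. Compound 3 gives > 25000 nM, which is a limit of the assay and not a number. The true size of the step cannot be read, because the measurement ends at a ceiling: the limit of > 25000 nM in this assay, at which 2 of the 3 values shown sit.

Going by these compounds, it stays open whether an aminophenyl or a carboxyphenyl group at this place would give a clear number in this assay.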